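The source may report more compounds than this note shows. Statements on the series, on what has been measured and on what is new or still open speak of the compounds shown alone.

Going by the values given here, in a functional assay on the whole organism for inhibition, with Rattus norvegicus as the target, with a stated time of 7 h, at a dose of 1 mg/kg by the oral route (on this read-out lower numbers stand for less inhibition and higher numbers for more inhibition at the one dose given (going by the name of the read-out)), compound 2 `CCCOc1nc2cccc(C(=O)O)c2n1Cc1ccc(-c2ccccc2-c2noc(O)n2)cc1` gives 100%, the higher of the two numbers measured so far. Compound 1 `COc1nc2cccc(C(=O)O)c2n1Cc1ccc(-c2ccccc2-c2noc(O)n2)cc1` gives 88% in this assay. Among the compounds with values here, the single measured step, a number 12 percentage points higher from compound 1 to compound 2 (beyond the scatter), came with ethyl in place of hydrogen on a saturated chain carbon bound to an oxygen on an aromatic ring. Compound 3 `CNc1nc2cccc(C(=O)O)c2n1Cc1ccc(-c2ccccc2-c2noc(O)n2)cc1` differs from compound 2 by methylamino in place of propoxy on an aromatic carbon. Within the data shown here, that measured step bears only loosely on this change: it shows a longer chain on the oxygen going with more inhibition, whereas here the chain grows shorter and the oxygen is replaced by nitrogen, a swap that no measured pair covers. Compound 2 at 100% also leaves no room upward. A downward step is therefore expected, estimated as a number 18 percentage points lower from compound 2 to compound 3 (beyond the scatter). Compound 3 is estimated to give 82% in this assay, within a range from 55% to 100%.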

Compound 3, a percentage reported as inhibition, in the whole organism at one dose (the size of the read-out at that dose, not a potency): 13%
Compound 3: the middle estimate sits 69 percentage points above what was measured; measured number below the stated range.
By their numbers in this assay, from the lowest: compound 3; then compound 1; then compound 2.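

At this position, on an aromatic carbon between two ring nitrogen atoms, the atom that links the group to the core matters far more than the earlier chain change suggested. In this assay, methylamino in place of propoxy gives a number 87 percentage points lower from compound 2 to compound 3 (beyond the scatter), and methylamino in place of methoxy gives a number 75 percentage points lower from compound 1 to compound 3 (beyond the scatter), so even the short oxygen-linked group keeps far more inhibition than methylamino. Nothing measured here explains this loss of inhibition.

The compounds shown do not separate the effect of the nitrogen from that of its short chain, and a propylamino group would test nitrogen with the same chain length as propoxy. A dimethylamino group would show whether the hydrogen-bond donor of methylamino is tied to the drop.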